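The source may hold more compounds than are shown below. What is called first, only, known or untested is meant among the compounds shown, and "the series" means these compounds.

In an ADME assay on MRC5 cells (Homo sapiens) for inhibition, read by MTT assay, with a stated time of 72 h (a higher number here means a weaker inhibitor, a lower number a stronger inhibitor), compound 1, `O=C(OCCCCCCO)OCCc1ccc(OCc2ccccc2)c(OCc2ccccc2)c1`, gives only a limit, > 50000 nM, and no number. Compound 2, `O=C(OCCCCCCOC(=O)OCCc1ccc(OCc2ccccc2)c(OCc2ccccc2)c1)OCCc1ccc(OCc2ccccc2)c(OCc2ccccc2)c1`, has "not determined" (no result reported) in this assay. Compound 3, `O=C(OCCCCO)OCCc1ccc(O)c(O)c1`, also has "not determined" (no result reported) in this assay, so it stands without a number of its own. Beside it, compound 1 sits at a limit, (the limit of > 50000 nM in this assay, at which 1 of the 3 values shown sits), and one further entry stands without a number. Compound 4, `CCCCCCCCCOC(=O)OCCc1ccc(O)c(O)c1`, differs from compound 3 in one place: pentyl in place of hydroxy on a saturated chain carbon, four bonds along the chain from an oxygen next to a carbonyl group. Among the compounds with values here, no measured step joins these two compounds, so no size of step in this assay can be read from the data; with compound 1 sitting at the limit, a weak inhibition, if any, is expected. Compound 4 is estimated at 40000 nM, within 8000 nM to 200000 nM.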

Compound 4, half-maximal inhibitory concentration: 15900 nM
Estimate against measurement, compound 4: 2.5-fold (0.40 log units) above, within the range that was stated.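

No step can be read here: compound 3 has no number of its own to set against compound 4. Left open is how far pentyl in place of hydroxy shifts inhibition, since compound 1 gives only a limit: the limit of > 50000 nM in this assay, at which 1 of the 4 values shown sits.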